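This account rests on a few compounds, and the source may have more. Where it says the series, first, only, none or still open, it means among the compounds named here.

Measured so far in a functional assay on FM3A cells (Mus musculus) for antiproliferative activity, read by cell counting, with a stated time of 2 days; on this read-out higher numbers stand for weaker inhibition and lower numbers for stronger inhibition 
- compound 1 `COc1ccc(Nc2nc(N)c(C(=O)c3ccccc3)s2)cc1` gives 730 nM 
- compound 2 `COc1ccc(Nc2nc(N)c(C(=O)c3ccc(OC)c(OC)c3)s2)cc1` gives 71 nM 
- compound 3 `COc1cccc(C(=O)c2sc(Nc3ccccc3)nc2N)c1` gives 6200 nM 

Compound 3 has the highest number of the three, beyond the scatter from both others. Compound 4 `COc1ccc(Nc2nc(N)c(C(=O)c3cccc(OC)c3)s2)cc1` differs from it by methoxy in place of hydrogen on an aromatic carbon (methoxy in place of hydrogen on an aromatic carbon, para to a large group, so phenyl becomes 4-methoxyphenyl). Going by the values given here, no measured pair isolates this change. Compound 1 at 730 nM and compound 2 at 71 nM both carry 4-methoxyphenyl, though their other ends differ from that of compound 4. Stronger inhibition, beyond the scatter, is therefore expected, with an expected 21-fold lower number from compound 3 to compound 4 (1.32 log units; beyond the scatter) in this assay as the estimated step. Compound 4 is estimated at 300 nM within a range (80 nM to 1100 nM).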

Compound 4, half-maximal inhibitory concentration: 50 nM
Beside the measured number, compound 4's estimate is 6.0-fold (0.78 log units) above it; measured number below the stated range.
By their numbers in this assay, from the lowest: compounds 4 and 2 (each within the scatter of the next); then compound 1; then compound 3.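

In this assay, going by these compounds alone, methoxy in place of hydrogen para to a large group, turning phenyl into 4-methoxyphenyl, gives a 120-fold lower number from compound 3 to compound 4 (2.09 log units; beyond the scatter), the first direct reading of this change. At the other end of the molecule, methoxy in place of hydrogen gives a 15-fold lower number from compound 1 to compound 4 (1.16 log units; beyond the scatter), while hydrogen in place of a methoxy there gives a 1.4-fold lower number from compound 2 to compound 4 (0.15 log units; within the scatter), so removing that methoxy does not move the number beyond the scatter. No measurement shown gives a cause for these steps. Within the data shown here, only one pair reads the 4-methoxyphenyl change, so whether it holds with other ends remains open. Also open, going by these compounds, is how an ethoxy or an amine would behave in that place.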